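The compounds below may be only part of what the source reports. "The series", "measured", "known", "first", "only" and "open" are said of these compounds alone.

Compound 2 `CN(C)CCN1CCN(CC(=O)Nc2ccc(-c3nc4cc(Cl)ccc4o3)cc2)CC1` stands second highest of the three numbers in a functional assay on MCF7 cells (Homo sapiens) for cytotoxicity, read by MTT assay, with a stated time of 24 h (on this read-out lower numbers stand for stronger inhibition and higher numbers for weaker inhibition), where compound 2 gives 7920 nM; compound 3 `CN(C)CCCN1CCN(CC(=O)Nc2ccc(-c3nc4cc(Cl)ccc4o3)cc2)CC1` gives 1650 nM and compound 1 `Cc1cc(-c2nc3ccccc3o2)ccc1NC(=O)CN1CCN(CCN(C)C)CC1` gives 41600 nM. Among the measured compounds shown here, the only single-place step among the measured compounds is a 4.8-fold lower number from compound 2 to compound 3 (0.68 log units; beyond the scatter), and it concerns the chain rather than the aromatic ring. Compound 4 `Cc1cc(-c2nc3cc(Cl)ccc3o2)ccc1NC(=O)CN1CCN(CCN(C)C)CC1` differs from compound 2 by methyl in place of hydrogen on an aromatic carbon. Compound 1 carries a methyl but not the 5-chloro-1,3-benzoxazol-2-yl group, and differs from compound 2 in two places, so its higher number cannot be assigned to either change. For the measured compounds named here, no measured step bears on a methyl on the aromatic ring, so the expected step is a 1.5-fold higher number from compound 2 to compound 4 (0.18 log units; within the scatter), expected to stay near the scatter. Compound 4 is estimated at 12000 nM, within 4000 nM to 40000 nM.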

Compound 4, half-maximal inhibitory concentration: 39300 nM
For compound 4 the middle estimate is 3.3-fold (0.52 log units) below the measured one; the range from low to high includes it.
By their numbers in this assay, from the lowest: compound 3; then compound 2; then compounds 4 and 1 (each within the scatter of the next).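

In this assay the methyl, ortho to a large group and meta to a 5-chloro-1,3-benzoxazol-2-yl group, brings a 5.0-fold higher number from compound 2 to compound 4 (0.70 log units; beyond the scatter) and so moves the number beyond the scatter. Chloro in place of hydrogen, with that methyl present, brings only a 1.1-fold lower number from compound 1 to compound 4 (0.02 log units; within the scatter) and stays within it. The gap that could not be assigned for compound 1 therefore follows the methyl rather than the chloro on this pair. Nothing here explains the size of the methyl step. From the compounds shown here alone, whether an ethyl or a methoxy on the same aromatic carbon would give a similar step remains open, as does the methyl's effect with the longer chain of compound 3.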